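Replacing a Bromophenyl with Pyridin-2-yl: An Untested Step

The source may report more compounds than this note shows. Statements on the series, on what has been measured and on what is new or still open speak of the compounds shown alone.

The compounds here were compared in an assay on CHO cells for displacement of a labelled ligand from melanin-concentrating hormone receptor 1 (Homo sapiens), read by scintillation counting, with a stated time of 1 h; on this read-out lower numbers stand for stronger inhibition and higher numbers for weaker inhibition. Compound 1 `Cc1c(C2CC2)nc2ccc(NC(=O)COc3ccc(OC(F)(F)F)cc3)cn12` gives 3 nM in this assay, and compound 2 `Cc1c(C2CC2)nc2ccc(-n3ccc(OCc4ccc(Br)cc4)cc3=O)cn12` gives 12 nM. Of the two numbers that are known, compound 2 has the higher one, and its distance from compound 1 is wider than the usual scatter of repeated measurements. Compound 3 `COCc1nc2ccc(-n3ccc(OCc4ccc(F)cc4)cc3=O)cn2c1C` is different from both: in this assay it reached only the limit of > 1000 nM, a boundary of the assay rather than a number, as noted in the limit of > 1000 nM in this assay, at which 1 of the 3 values shown sits.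

Compound 4 `Cc1c(C2CC2)nc2ccc(-n3ccc(OCc4ccccn4)cc3=O)cn12` has not been measured. It is built from compound 2 by a single change, pyridin-2-yl in place of 4-bromophenyl on a saturated chain carbon bound to an oxygen on an aromatic ring. Within the data shown here, no pair of measured compounds shows this exact exchange, so its effect can only be guessed from the change itself. The bromine leaves and a ring nitrogen enters, and the modest expectation is a somewhat weaker binding, a step of a 3.3-fold higher number from compound 2 to compound 4 (0.52 log units; beyond the scatter) that may or may not exceed the scatter. Compound 4 is therefore estimated at 40 nM, within a range from 10 nM to 200 nM.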

Compound 4, half-maximal inhibitory concentration: 240 nM
For compound 4 the middle estimate is 6.0-fold (0.78 log units) below the measured one; the whole stated range lies below it.
By their numbers in this assay, from the lowest: compound 1; then compound 2; then compound 4. At a limit, above all of these: compound 3.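

The exchange of 4-bromophenyl for pyridin-2-yl, on a saturated chain carbon bound to an oxygen on an aromatic ring, gives a 20-fold higher number from compound 2 to compound 4 (1.30 log units; beyond the scatter) in this assay, a large step well beyond the scatter. The earlier compounds shown here offered no pair differing in one place, so they could not show how much this end of the molecule counts on its own; here the rest of the structure stays the same, and the whole step belongs to this one exchange. The data shown offer no measurement that explains why the step is this large.

The bromine leaves and a ring nitrogen enters in the same exchange, so the compounds shown leave open which of the two changes carries the step, and whether the position of the nitrogen in the ring matters. A plain phenyl or a 4-chlorophenyl at this place would speak to the role of the bromine, and a pyridin-3-yl or pyridin-4-yl would speak to the role of the ring nitrogen and its position.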